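Chloro for methyl on the indazole of compound 2

The source may hold more compounds than are shown below. What is called first, only, known or untested is meant among the compounds shown, and "the series" means these compounds.

Measured so far:
compound 1, `CCC/C(=C(/c1ccc(/C=C/C(=O)O)cc1)c1ccc2[nH]ncc2c1)c1ccccc1`, 11 nM
compound 2, `CC/C(=C(/c1ccc(/C=C/C(=O)O)cc1)c1ccc2[nH]nc(C)c2c1)c1ccccc1`, > 1000 nM

In a functional assay on MCF7 cells (Homo sapiens) for cytotoxicity, read by CellTiter-Glo, with a stated time of 5 days (on this read-out lower numbers stand for stronger inhibition and higher numbers for weaker inhibition), compound 1 gives 11 nM. In this assay compound 2 gives > 1000 nM, which is a limit of the assay and not a number. For the measured compounds named here, compound 2 thus stands at the limit of > 1000 nM in this assay, at which 1 of the 2 values shown sits, so its true potency is known only as weaker than that bound, and the two compounds also differ in more than one place, so no single step between them can be read.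

Compound 3, `CC/C(=C(/c1ccc(/C=C/C(=O)O)cc1)c1cc2cn[nH]c2cc1Cl)c1ccccc1`, is the next compound to be measured in this assay. It differs from compound 2 in one place: 6-chloro-1H-indazol-5-yl in place of 3-methyl-1H-indazol-5-yl on a double-bonded chain carbon bound to an aromatic carbon and a double-bonded chain carbon. Going by the values given here, no measured step covers this change, so the expectation rests on the limit seen for compound 2 and on the value of compound 1. Compound 1 carries an unsubstituted indazole and gives 11 nM. The step of an at least 10-fold lower number from compound 2 to compound 3 (1.00 log units; beyond the scatter) is expected to run toward stronger inhibition, beyond the scatter, with the chloro-bearing indazole recovering part of what the methyl-bearing one lost. Compound 3 is expected to give 100 nM, within a range of 10 nM to 1000 nM.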

Compound 3, half-maximal inhibitory concentration: 137 nM
For compound 3 the middle estimate is 1.4-fold (0.14 log units) below the measured one, within the range that was stated.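

In this assay, for the compounds shown here, 6-chloro-1H-indazol-5-yl in place of 3-methyl-1H-indazol-5-yl gives an at least 7.2-fold lower number from compound 2 to compound 3 (0.86 log units; beyond the scatter), the first step that can be read across a single place. It shows that a substituted indazole at this place on the double-bonded chain carbon need not sit at the assay limit, although the two group names differ both in the substituent and in its number on the indazole, so the step cannot be assigned to either alone. Compound 2 stands at a limit of the assay and not at a number, so the step gives only a bound: the limit of > 1000 nM in this assay, at which 1 of the 3 values shown sits.

Steps involving compound 1 cannot be read, as it differs from compound 2 and from compound 3 in more than one place. Open questions are how 3-chloro-1H-indazol-5-yl and 6-methyl-1H-indazol-5-yl would read in this assay, which would separate the substituent from its place on the indazole, and whether a fluorine or a methoxy group at the same place would follow the chlorine.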